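A few compounds are considered here, and "the series" means these few. Any claim that something is new, unique, unknown or untested is made for them only; others in the source may bear on it.

Of the compounds shown here, two sharing one core have been measured. In a functional assay on HeLa cells (Homo sapiens) for antiproliferative activity, read by sulforhodamine B assay, with a stated time of 48 h (on this read-out lower numbers stand for stronger inhibition and higher numbers for weaker inhibition), compound 1 `O=C(Nc1ccccc1)Nc1ccc(S(=O)(=O)Nc2ccnc3cc(C(F)(F)F)ccc23)cc1` gives 41000 nM. Compound 2 `Cc1cc(NS(=O)(=O)c2ccc(N/C(S)=N\c3ccnc4cc(C(F)(F)F)ccc34)cc2)on1` gives 60200 nM in this assay, and the two numbers lie within the usual scatter of each other, so neither can be called stronger or weaker. Compound 3 `Cc1ccnc(NS(=O)(=O)c2ccc(N/C(S)=N\c3ccnc4cc(C(F)(F)F)ccc34)cc2)n1` differs from compound 2 in one place: 4-methylpyrimidin-2-yl in place of 3-methyl-1,2-oxazol-5-yl on a sulfonamide nitrogen. Going by the values given here, no measured pair shows this change, so the expected step of a 1.2-fold lower number from compound 2 to compound 3 (0.08 log units; within the scatter) is taken as none beyond the scatter. Compound 3 is therefore estimated at 50000 nM, with a range from 18000 nM to 140000 nM.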

Compound 3, half-maximal inhibitory concentration: 31000 nM
Compound 3: middle estimate off by 1.6-fold (0.21 log units), on the high side, and the stated range covers the measured number.
By their numbers in this assay, from the lowest: compounds 3, 1 and 2 (each within the scatter of the next).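

In this assay, 4-methylpyrimidin-2-yl in place of 3-methyl-1,2-oxazol-5-yl on a sulfonamide nitrogen gives a 1.9-fold lower number from compound 2 to compound 3 (0.29 log units; within the scatter), a step within the usual scatter. At this position, then, a six-membered aromatic ring and a five-membered one cannot be told apart in this pair. Nothing measured here offers an explanation for this result. Still open, on these data alone, is whether a different kind of group on this nitrogen, such as an acetyl group or a longer alkyl chain, would give a step beyond the scatter. One pair also cannot show whether the same swap behaves alike on other cores.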